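Nitro in place of cyano: expected potency of compound 3

A few compounds are considered here, and "the series" means these few. Any claim that something is new, unique, unknown or untested is made for them only; others in the source may bear on it.

Two compounds of the series have been run in a functional assay (Cavia porcellus) with sulfonylurea receptors; K-ATP channels (Homo sapiens) as the target; on this read-out lower numbers stand for stronger inhibition and higher numbers for weaker inhibition. Going by the values given here, compound 1 `CC(O)(C(=O)Nc1ccc(S(=O)(=O)c2ccccc2)c(C#N)c1)C(F)(F)F` is the only member for which a number exists: in this assay compound 1 gives 3800 nM. The other value shown is the limit of > 30000 nM in this assay, at which 1 of the 2 values shown sits; it belongs to compound 2 `CC(O)(C(=O)Nc1ccc(S(=O)(=O)c2cccc(C(F)(F)F)c2)cc1)C(F)(F)F`, which in this assay gives > 30000 nM, a limit of the assay rather than a number. Among the compounds with values here, no step between two measured compounds can be drawn from these two entries, so the series so far holds no measured change to compare against.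

Compound 3 `CC(O)(C(=O)Nc1ccc(S(=O)(=O)c2ccccc2)c([N+](=O)[O-])c1)C(F)(F)F` has not been measured. It differs from compound 1 by nitro in place of cyano on an aromatic carbon, the position being ortho to the phenylsulfonyl group and meta to a large group. Within the data shown here, with no measured step of this kind available, the expectation is a change of no more than the usual scatter, in either direction. Compound 3 is expected to give 3500 nM in this assay, within a range of 1200 nM to 11000 nM. The expected step is a 1.1-fold lower number from compound 1 to compound 3 (0.04 log units; within the scatter).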

Compound 3, half-maximal inhibitory concentration: > 30000 nM
Compound 3: only a limit was reported (the forecaster's own chance of this, stated with the estimate: 12%); at least 8.5-fold (0.93 log units) between middle value and limit.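

Nitro in place of cyano, on the aromatic carbon ortho to the phenylsulfonyl group, gives an at least 7.8-fold higher number from compound 1 to compound 3 (0.89 log units; beyond the scatter), the only measured step in the series so far. This shows that the position does not accept every replacement of the nitrile, and that a change of one group here can take the compound from a measured number to a limit in this assay. Compound 1 remains the only compound with a number, and the size of the step has only a lower bound, as compound 3 now also stands at a limit of the assay rather than a number: the limit of > 30000 nM in this assay, at which 2 of the 3 values shown sit.

What the compounds shown leave open is whether the nitrile is specifically needed at this position or nitro alone is poorly accepted, which a chlorine, a methyl or an amine on the same carbon would help to separate. Also open, going by these compounds, is whether the position tolerates anything larger than the nitrile, such as a methyl ketone or a carboxamide, and whether any replacement there gives a lower number than compound 1.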